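Working notes on the thiocarbonyl terminus: compound 2 to compound 3

The source may hold more compounds than are shown below. What is called first, only, known or untested is meant among the compounds shown, and "the series" means these compounds.

Two compounds of the series have been run in a functional assay on K562 cells (Homo sapiens) for cytotoxicity, read by sulforhodamine B assay; a higher number here means that more compound is tolerated, a lower number that less compound is tolerated. Compound 1 `CC1=CC[C@@H]([C@@](C)(O)CCCC(C)(C)NC=S)CC1` reaches only the assay limit: in this assay compound 1 gives > 100000 nM, a limit rather than a number. For the measured compounds named here, compound 2 `CC1=CC[C@@H]([C@@](C)(O)CCCC(C)(C)NC(=S)NN)CC1` is the one compound with a measured number: in this assay compound 2 gives 9580 nM. Going by the values given here, the single measured step, an at least 10-fold lower number from compound 1 to compound 2 (1.01 log units; beyond the scatter), is bounded on one side by the limit of > 100000 nM in this assay, at which 1 of the 2 values shown sits, so only its lower bound is known.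

Compound 3 `CC1=CC[C@@H]([C@@](C)(O)CCCC(C)(C)NC(=S)N/N=C\c2ccccc2)CC1` is not yet measured. Its change from compound 2 is a group of 8 heavy atoms (7 carbon, 1 nitrogen; one six-membered aromatic ring of carbon only) in place of one nitrogen atom, on an amide-type nitrogen; in words, a group of 8 heavy atoms (7 carbon, 1 nitrogen; one six-membered aromatic ring of carbon only) in place of one nitrogen atom, on an amide-type nitrogen. Among the compounds with values here, no measured step alters exactly this position; the one step that exists builds up the same end of the molecule, and it lowered the number by a large margin. That direction is taken as the guide, with a smaller size assumed. The expectation for compound 3 in this assay is a step of a 3.2-fold lower number from compound 2 to compound 3 (0.50 log units; beyond the scatter), toward a lower number. The estimate for compound 3 is 3000 nM, with a range from 800 nM to 15000 nM.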

Compound 3, concentration lethal to 50% of the cells: > 100000 nM
Compound 3: a limit, no number; the forecaster's own chance of this, stated with the estimate: 5%; middle value at least 33-fold (1.52 log units) from the limit.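

Replacing the amino on the amide-type nitrogen with a group of 8 heavy atoms carrying one six-membered aromatic ring of carbon only gives an at least 10-fold higher number from compound 2 to compound 3 (1.01 log units; beyond the scatter) in this assay, so the direction of the earlier step at this end of the molecule does not carry over to this change. Among the compounds shown, a measured number appears only with the terminal amino of compound 2, and neither the simple thiocarbonyl terminus of compound 1 nor the larger terminus of compound 3 gives one. The step from compound 1 to compound 3 cannot be read, and the step from compound 2 to compound 3 gives only a lower bound, since the series now rests mainly on a limit: the limit of > 100000 nM in this assay, at which 2 of the 3 values shown sit.

Going by these compounds, whether the higher number goes with the aromatic ring or with the double bond outside it stays open, as does the reading of a small group such as methyl or acetyl on the same nitrogen. Also open, on these data alone, is whether a phenyl ring bearing a methoxy group or a carboxylic acid would return a measured number.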